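Carboxy to isopropyl on the aryl ether of compound 3

The source may hold more compounds than are shown below. What is called first, only, known or untested is meant among the compounds shown, and "the series" means these compounds.

Compound 1 `O=c1ccn(CCCCCOc2ccc([N+](=O)[O-])cc2)c(=O)[nH]1` carries a nitro group on its aromatic ring, and in an ADME assay on HEL cells (Homo sapiens) for cytotoxicity, read by microscopy (a higher number here means that more compound is tolerated, a lower number that less compound is tolerated), compound 1 gives 20000 nM. Compound 2 `Nc1ccc(OCCCCCn2ccc(=O)[nH]c2=O)cc1` reaches only a limit of the assay, with compound 2 giving > 100000 nM. Compound 3 `O=C(O)c1ccc(OCCCCCn2ccc(=O)[nH]c2=O)cc1` likewise reaches only a limit, with compound 3 giving > 100000 nM. Compound 3 therefore stands at the top edge of what the assay reports, a place it shares with compound 2 (the limit of > 100000 nM in this assay, at which 2 of the 3 values shown sit). The measured steps are an at least 5.0-fold higher number from compound 1 to compound 2 (0.69 log units; beyond the scatter) and an at least 5.0-fold higher number from compound 1 to compound 3 (0.69 log units; beyond the scatter), while a step that the two limits leave unreadable from compound 2 to compound 3.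

Compound 4 `CC(C)c1ccc(OCCCCCn2ccc(=O)[nH]c2=O)cc1` differs from compound 3 by isopropyl in place of carboxy on an aromatic carbon. Among the compounds with values here, no measured step exchanges carboxy for isopropyl, so the two readable steps, both moving away from nitro, offer only indirect guidance, and the third step is unreadable. Compound 4 is expected to land at about 50000 nM, somewhere between 15000 nM and 100000 nM, which means an expected at least 2.0-fold lower number from compound 3 to compound 4 (0.30 log units; that floor lies within the scatter).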

Compound 4, minimum cytotoxic concentration: 100000 nM
For compound 4 the middle estimate is 2.0-fold (0.30 log units) below the measured one; the range from low to high includes it.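

In this assay compound 4 gives 100000 nM, so replacing nitro with isopropyl also raises the tolerated concentration, and here the size can be read as a full number rather than a limit. The step is modest: a 5.0-fold higher number from compound 1 to compound 4 (0.70 log units; beyond the scatter). Isopropyl has no hydrogen-bond donors or acceptors, whereas carboxy has one of each, so at this position the rise on leaving nitro does not depend on having those features. The remaining steps are a number no higher from compound 3 to compound 4 (the limit leaves the size open) and a number no higher from compound 2 to compound 4 (the limit leaves the size open), and their sizes cannot be read because compound 2 and compound 3 sit at a limit: the limit of > 100000 nM in this assay, at which 2 of the 4 values shown sit.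

Going by these compounds, whether amino, carboxy and isopropyl truly differ from one another therefore stays open. So does whether a chlorine or a nitrile on this aromatic carbon would keep the number of compound 4 or return it toward that of compound 1.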